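The source may hold more compounds than are shown below. What is called first, only, known or untested is meant among the compounds shown, and "the series" means these compounds.

Measured compounds in an ADME assay on Caco-2 cells (Homo sapiens) for permeability, in the apical to basolateral direction; a higher number here means that the compound crosses the layer faster, a lower number that the compound crosses the layer more slowly:

compound 1, `Cn1cncc1CN1CC(N(CC2CCN(C(=O)c3ccc(Cl)cc3)CC2)S(=O)(=O)c2ccccn2)Cc2cc(C#N)ccc21`: 0.5 10^-6 cm/s
compound 2, `CCC(=O)N1CCC(CN(C2Cc3cc(C#N)ccc3N(Cc3cncn3C)C2)S(=O)(=O)c2ccccn2)CC1`: 0.5 10^-6 cm/s
compound 3, `CCS(=O)(=O)N1CCC(CN(C2Cc3cc(C#N)ccc3N(Cc3cncn3C)C2)S(=O)(=O)c2ccccn2)CC1`: 0.1 10^-6 cm/s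

Compound 2 sits level with compound 1 at the digits shown, and the two together give the highest numbers of the three in this assay; compound 3 is the furthest from compound 2, a 5.0-fold lower number from compound 2 to compound 3 (0.70 log units; beyond the scatter).

The step to be followed runs from compound 2 to compound 4, `CCOC(=O)N1CCC(CN(C2Cc3cc(C#N)ccc3N(Cc3cncn3C)C2)S(=O)(=O)c2ccccn2)CC1`, still to be measured in this assay. The change is ethoxy in place of ethyl on a carbonyl carbon, so the carbonyl on the ring nitrogen stays and only its far-side substituent is exchanged, propanoyl to ethoxycarbonyl.

Among the compounds with values here, two measured steps bear on this position. The swap of the acyl substituent on the same carbonyl carbon, no change at the digits printed from compound 1 to compound 2 (within the scatter), left the number unchanged despite a much larger change in the group. Replacing the carbonyl group itself, a 5.0-fold lower number from compound 2 to compound 3 (0.70 log units; beyond the scatter), gave a modest drop, but that step removes the carbonyl, which the present change does not. An acyl-to-acyl exchange at this carbonyl is therefore expected to move the number little, if at all: the expected step is no change at the digits printed from compound 2 to compound 4 (within the scatter), within the scatter.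

Compound 4 is thus estimated at 0.5 10^-6 cm/s in this assay, with an expected range from 0.2 10^-6 cm/s to 1 10^-6 cm/s.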

Compound 4, apparent permeability: 2.6 10^-6 cm/s
Compound 4: middle estimate off by 5.2-fold (0.72 log units), on the low side; measured number above the stated range.
By their numbers in this assay, from the lowest: compound 3; then compounds 1 and 2 (each within the scatter of the next); then compound 4.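

In this assay the substituent on this carbonyl carbon does move the number: ethoxy in place of ethyl gives (a 5.2-fold higher number from compound 2 to compound 4 (0.72 log units; beyond the scatter)) while ethyl in place of 4-chlorophenyl at the same carbon gave (no change at the digits printed from compound 1 to compound 2 (within the scatter)) and ethoxy in place of 4-chlorophenyl gives (a 5.2-fold higher number from compound 1 to compound 4 (0.72 log units; beyond the scatter)). Within the data shown here, the group on the ring nitrogen therefore matters more than the earlier compounds showed, and ethoxycarbonyl in place of ethylsulfonyl gives the largest step of the set (a 26-fold higher number from compound 3 to compound 4 (1.41 log units; beyond the scatter)), so retaining the carbonyl does not by itself fix the number, as compounds 1, 2 and 4 all keep it. No measurement shown here accounts for the rise from propanoyl to ethoxycarbonyl.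

The compounds shown leave open whether the higher number follows from the oxygen on the carbonyl carbon or from the ethoxy group as a whole, which methoxy, tert-butoxy or dimethylamino on that carbon would help to separate. They also leave open whether the step from ethyl to ethoxy would recur with a different sulfonyl group on the shared core.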